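Swapping one pyridine group on compound 1

A few compounds are considered here, and "the series" means these few. Any claim that something is new, unique, unknown or untested is made for them only; others in the source may bear on it.

Measured so far in an ADME assay on microsomes from liver (Homo sapiens) for metabolic stability; on this read-out higher numbers stand for a longer-lived compound and lower numbers for a shorter-lived compound
Compound 1 `COc1nc2ccc(Br)cc2cc1[C@@H](c1cncc(C)c1)[C@@](O)(CCN(C)C)c1cccc(F)c1` gives 0.2 h
Compound 2 `COc1nc2ccc(Br)cc2cc1[C@@H](c1ccnc(OC)c1OC)[C@@](O)(CCN(C)C)c1cccc(C)c1` gives 0.867 h
Compound 3 `COc1nc2ccc(Br)cc2cc1[C@@H](c1ccnc(OC)c1OC)[C@@](O)(CCN(C)C)c1cccc(OC(F)F)c1` gives 1.02 h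

Compound 1 has the lowest number of the three, clearly under compound 2 and compound 3. Compound 4 `COc1cc([C@H](c2cc3cc(Br)ccc3nc2OC)[C@@](O)(CCN(C)C)c2cccc(F)c2)cnc1OC` differs from compound 1 at one place, where 5,6-dimethoxypyridin-3-yl stands in place of 5-methylpyridin-3-yl (5,6-dimethoxypyridin-3-yl in place of 5-methylpyridin-3-yl on a saturated chain carbon bound to an aromatic carbon and a saturated chain carbon). For the measured compounds named here, the only measured step (a 1.2-fold higher number from compound 2 to compound 3 (0.07 log units; within the scatter)) lies elsewhere in the structure and within the scatter, so no measured step tests this swap directly. The higher numbers of compound 2 (0.867 h) and compound 3 (1.02 h) offer only a weak hint of where compound 4 may land. In this assay a modest rise is expected, estimated as a 2.3-fold higher number from compound 1 to compound 4 (0.35 log units; beyond the scatter) with real uncertainty. Compound 4 is therefore estimated at 0.45 h ranging from 0.18 h to 1.1 h at this stage.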

Compound 4, half-life: 0.317 h
Compound 4: middle estimate off by 1.4-fold (0.15 log units), on the high side; measured number inside the range.
By their numbers in this assay, from the lowest: compounds 1 and 4 (each within the scatter of the next); then compounds 2 and 3 (each within the scatter of the next).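

In this assay, for the compounds shown here, the swap to 5,6-dimethoxypyridin-3-yl in place of 5-methylpyridin-3-yl on this saturated chain carbon gives a 1.6-fold higher number from compound 1 to compound 4 (0.20 log units; within the scatter) and so provides the first direct reading at this position. Enlarging the group from 7 to 10 heavy atoms therefore leaves the half-life within normal repeat variation on the core of compound 1. Nothing available gives a reason for this result.

Going by these compounds, whether a morpholine or a pyridine bearing an amine or a nitrile at this position would move the half-life beyond the scatter remains open.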